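Chloro in place of methoxy on the phenyl of compound 3

The source may hold more compounds than are shown below. What is called first, only, known or untested is meant among the compounds shown, and "the series" means these compounds.

Of the compounds shown here, two built on a shared core have been tested in a functional assay on U-87MG ATCC cells for antiproliferative activity against U-87 MG (Homo sapiens), read by MTT assay, with a stated time of 48 h, tested at 5 uM; a lower number here means a stronger effect, a higher number a weaker effect of the compound at the concentration tested. In this assay compound 1 `Cc1nc(-c2ccc(Cl)cc2)sc1C(=O)CSc1nc(-c2ccccc2)c(C#N)c(=O)[nH]1` gives 88.9%. In this assay compound 2 `COc1ccc(-c2nc(SCC(=O)c3sc(-c4ccc(Cl)cc4)nc3C)[nH]c(=O)c2C#N)cc1` gives 92.1%. Among the measured compounds shown here, the single step between them, a number 3.2 percentage points higher from compound 1 to compound 2 (within the scatter), is methoxy in place of hydrogen on an aromatic carbon, and it lies within the scatter. Compound 2 thus holds the highest of the two numbers, with compound 1 the nearest and within the scatter of it, so neither can be called the stronger one.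

Compound 3 `Cc1nc(-c2ccc(Cl)cc2)sc1C(=O)CSc1nc(-c2ccc(Cl)cc2)c(C#N)c(=O)[nH]1` differs from compound 2 by chloro in place of methoxy on an aromatic carbon. For the measured compounds named here, no measured step covers a chloro entering where a methoxy leaves; the only step at hand, which put the methoxy onto that carbon, stayed within the scatter. With nothing in the measured pair pointing beyond the scatter, the estimate for compound 3 is an unchanged read-out rather than a step in either direction. Compound 3 is therefore expected to give 90% in this assay, between 78% and 100%. That estimate means an expected step of a number 2.1 percentage points lower from compound 2 to compound 3 (within the scatter).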

Compound 3, a percentage reported as activity, at one concentration (the size of the read-out at that concentration, not a potency): 99%
Estimate against measurement, compound 3: 9 percentage points below; the measured number falls inside the stated range.
By their numbers in this assay, from the lowest: compounds 1, 2 and 3 (each within the scatter of the next, the first and the last beyond it).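

In this assay, among the compounds shown here, the change from hydrogen to chloro on this aromatic carbon, para to a large group, gives a number 10.1 percentage points higher from compound 1 to compound 3 (beyond the scatter), the first step at this position to lie beyond the scatter, and it goes towards a weaker effect at the concentration tested. The change from 4-methoxyphenyl to 4-chlorophenyl on the same carbon gives a number 6.9 percentage points higher from compound 2 to compound 3 (within the scatter), so methoxy and chloro cannot be told apart here, even though only the chloro stands clear of the hydrogen of compound 1. No measurement shown here explains why the chloro step is the one that clears the scatter.

On these data alone, the three compounds cover only hydrogen, methoxy and chloro at this position, so it remains open whether an amine or a carboxylic acid on this carbon would bring the number below that of compound 1. As far as these compounds go, it also remains open whether the modest chloro step would hold with the same group on another carbon of the phenyl ring, or with a fluoro or a bromo in its place.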